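This account rests on a few compounds, and the source may have more. Where it says the series, first, only, none or still open, it means among the compounds named here.

Measured in an ADME assay on FSCLL cells (Homo sapiens) for cytotoxicity, read by MTT assay, with a stated time of 24 h; on this read-out lower numbers stand for higher toxicity in this test and higher numbers for lower toxicity in this test:
- Compound 1 `CNCC(=O)N[C@@H](CC(C)C)B(O)O`: 160 nM
- Compound 2 `CC(C)C[C@H](NC(=O)[C@H](C)N)B(O)O`: 3200 nM

Compound 2, at 3200 nM, holds the higher of the two numbers, so it is the less toxic in this assay. Compound 3 `CCCC[C@H](N)C(=O)N[C@@H](CC(C)C)B(O)O` has propyl in place of hydrogen on a saturated chain carbon, two bonds along the chain from an amine nitrogen and a carbonyl carbon. Within the data shown here, the only measured step, a 20-fold higher number from compound 1 to compound 2 (1.30 log units; beyond the scatter), is large but reflects a different change, so it shows that small edits can matter without fixing a direction here. A moderate drop is tentatively expected, an estimated 2.1-fold lower number from compound 2 to compound 3 (0.33 log units; beyond the scatter). For compound 3 the estimated value is 1500 nM, with an expected range of 250 nM to 8000 nM.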

Compound 3, half-maximal cytotoxic concentration: 950 nM
Compound 3: middle estimate off by 1.6-fold (0.20 log units), on the high side, within the range that was stated.
By their numbers in this assay, from the lowest: compound 1; then compound 3; then compound 2.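

In this assay, propyl in place of hydrogen on this saturated chain carbon, which turns methyl into butyl, gives a 3.4-fold lower number from compound 2 to compound 3 (0.53 log units; beyond the scatter). So this position tolerates a larger chain, and here the larger chain goes with higher toxicity in this test, though the step is only modest. No measurement shown here accounts for the shift. Still open, as far as these compounds go, is whether a longer chain than butyl, a phenyl ring or a carboxylic acid on this carbon would lower the number further or raise it again.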